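A few compounds are considered here, and "the series" means these few. Any claim that something is new, unique, unknown or untested is made for them only; others in the source may bear on it.

Compound 1 `COc1ccc(/C=C/c2cc(OC)cc(OC)c2/C=C/C(=O)N2CCCCC2C)cc1`: 7660 nM
Compound 2 `C#CCNC(=O)/C=C/c1c(/C=C/c2ccc(OC)cc2)cc(OC)cc1OC`: 8280 nM
Compound 3 `COc1ccc(/C=C/c2cc(OC)cc(OC)c2/C=C/C(=O)NC(C)C)cc1`: 4020 nM

These values come from a functional assay on B16-F10 cells (Mus musculus) for inhibition, read by MTT assay, with a stated time of 48 h; a higher number here means a weaker inhibitor, a lower number a stronger inhibitor. Compound 3 lies within the scatter of compound 1, and it stands apart from compound 2 only modestly: a 2.1-fold lower number from compound 2 to compound 3 (0.31 log units; beyond the scatter).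

Compound 4 `CCCCCN(CCCCC)C(=O)/C=C/c1c(/C=C/c2ccc(OC)cc2)cc(OC)cc1OC` carries dipentylamino in place of isopropylamino on a carbonyl carbon. The nearest measured precedent is compound 1, which also lacks the amide hydrogen: a 1.9-fold lower number from compound 1 to compound 3 (0.28 log units; within the scatter). The other change at this carbonyl carbon gives a 1.1-fold higher number from compound 1 to compound 2 (0.03 log units; within the scatter). Within the data shown here, both stay within the scatter, but no measured compound carries dipentylamino. A small upward change is expected, a 1.5-fold higher number from compound 3 to compound 4 (0.17 log units; within the scatter). The estimate for compound 4 is 6000 nM, with an expected range from 2000 nM to 15000 nM.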

Compound 4, half-maximal inhibitory concentration: 9270 nM
Compound 4: middle estimate off by 1.5-fold (0.19 log units), on the low side, and the stated range covers the measured number.
By their numbers in this assay, from the lowest: compounds 3, 1, 2 and 4 (each within the scatter of the next, the first and the last beyond it).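

In this assay, dipentylamino on the carbonyl carbon stands apart from isopropylamino (a 2.3-fold higher number from compound 3 to compound 4 (0.36 log units; beyond the scatter)), yet it stays level with propargylamino (a 1.1-fold higher number from compound 2 to compound 4 (0.05 log units; within the scatter)) and with 2-methylpiperidin-1-yl (a 1.2-fold higher number from compound 1 to compound 4 (0.08 log units; within the scatter)). Loss of the amide hydrogen does not sort these values, since compound 2 keeps that hydrogen and still sits with compound 1 and compound 4. Chain size alone does not sort them either, as the small propargylamino group sits with the large dipentylamino group. Nothing given here explains why isopropylamino stands apart. Going by these compounds, whether a shorter diethylamino group or a chain ending in an amine would sit with isopropylamino or with dipentylamino remains open.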